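Triazole Lactam Series: Fluorophenyl Variant of Compound 1

A few compounds are considered here, and "the series" means these few. Any claim that something is new, unique, unknown or untested is made for them only; others in the source may bear on it.

Measured compounds:
compound 1 `COc1ccc(-n2cc(CN3C(=O)C[C@@H]4CC[C@@]3(C)C4(C)C)nn2)cc1` — 330 nM
compound 2 `CC1(C)[C@H]2CC[C@]1(C)N(Cc1cn(-c3ccccc3C#N)nn1)C(=O)C2` — 240 nM
compound 3 `CC1(C)[C@H]2CC[C@]1(C)N(Cc1cn(-c3ccc(C#N)cc3)nn1)C(=O)C2` — 250 nM

In a functional assay on PANC-1 cells (Homo sapiens) for inhibition, read by MTT assay, with a stated time of 24 h (a higher number here means a weaker inhibitor, a lower number a stronger inhibitor), compound 1 gives 330 nM, the highest of the three numbers, but the steps of a 1.3-fold lower number from compound 1 to compound 3 (0.12 log units; within the scatter) and a 1.4-fold lower number from compound 1 to compound 2 (0.14 log units; within the scatter) both stay within the scatter, so the three compounds cannot be told apart on these data.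

Compound 4 `CC1(C)[C@H]2CC[C@]1(C)N(Cc1cn(-c3cccc(F)c3)nn1)C(=O)C2` differs from compound 1 in one place: 3-fluorophenyl in place of 4-methoxyphenyl on an aromatic nitrogen. Among the compounds with values here, the steps that bear on this change are a 1.4-fold lower number from compound 1 to compound 2 (0.14 log units; within the scatter) and a 1.3-fold lower number from compound 1 to compound 3 (0.12 log units; within the scatter), each of them also exchanging 4-methoxyphenyl on an aromatic nitrogen for a different substituted phenyl, and each within the scatter; likewise a 1.0-fold higher number from compound 2 to compound 3 (0.02 log units; within the scatter) shows that moving the substituent around the phenyl made no difference beyond the scatter. A third substituted phenyl in the same position is therefore expected to give no step beyond the scatter in this assay, in either direction.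

Compound 4 is estimated at 300 nM, with a range from 150 nM to 600 nM. This estimate means an expected step of a 1.1-fold lower number from compound 1 to compound 4 (0.04 log units; within the scatter).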

Compound 4, half-maximal inhibitory concentration: 220 nM
For compound 4 the middle estimate is 1.4-fold (0.13 log units) above the measured one, and the stated range covers the measured number.
By their numbers in this assay, from the lowest: compounds 4, 2, 3 and 1 (each within the scatter of the next).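

In this assay, taking away the hydrogen-bond acceptor counted on 4-methoxyphenyl and bringing in 3-fluorophenyl gives a 1.5-fold lower number from compound 1 to compound 4 (0.18 log units; within the scatter), so this exchange leaves the number within the scatter. Compound 4 also cannot be told apart from the two nitrile-bearing compounds, with a 1.1-fold lower number from compound 3 to compound 4 (0.06 log units; within the scatter) and a 1.1-fold lower number from compound 2 to compound 4 (0.04 log units; within the scatter), which extends the flat picture at this position to a fluorine-bearing phenyl. Nothing available accounts for why these groups read alike.

All four compounds carry a substituted phenyl on the aromatic nitrogen, so the compounds shown do not tell whether this position responds to anything further removed from that type of group. A phenyl bearing an amine or a carboxylic acid, or a plain alkyl chain in place of the phenyl, could still give a step beyond the scatter.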